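Cytotoxicity notes on an oxalamide series

A few compounds are considered here, and "the series" means these few. Any claim that something is new, unique, unknown or untested is made for them only; others in the source may bear on it.

Measured so far in an ADME assay on TZM-b1 cells (Homo sapiens) for cytotoxicity, read by XTT assay, with a stated time of 3 days; a lower number here means that less compound is tolerated, a higher number that more compound is tolerated:
- compound 1 `Cc1nc(C(NC(=O)C(=O)Nc2ccc(F)cc2F)C2CCCCN2)sc1CO`: > 87000 nM
- compound 2 `Cc1nc(C(NC(=O)C(=O)NC2CCCCCC2)C2CCCCN2)sc1CO`: > 90000 nM

In this assay compound 1 gives > 87000 nM, which is a limit of the assay and not a number. Compound 2 gives > 90000 nM in this assay, again a limit rather than a number. The step that the two limits leave unreadable from compound 1 to compound 2 is therefore unreadable in size and direction, as the limit of > 87000 nM in this assay, at which 1 of the 2 values shown sits, and the limit of > 90000 nM in this assay, at which 1 of the 2 values shown sits, show. Among the compounds with values here, compound 2 thus stands at a limit, and the one further value shown is also a limit, so no ordering of the two can be stated.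

Compound 3 `Cc1nc(C(NC(=O)C(=O)Nc2ccc(C(F)(F)F)cc2)C2CCCCN2)sc1CO` differs from compound 2 by 4-(trifluoromethyl)phenyl in place of cycloheptyl on an amide-type nitrogen. Within the data shown here, the only measured step, a step that the two limits leave unreadable from compound 1 to compound 2, concerns the same amide-type nitrogen and exchanged an aryl group for the cycloheptyl, yet both ends sit at limits, so it gives no readable size to carry over. Nothing in the shown numbers points to a step beyond the scatter in either direction. Compound 3 is expected to give 90000 nM, in the range 40000 nM to 150000 nM, most likely again as a limit, which means an expected step of a number no higher from compound 2 to compound 3 (the limit leaves the size open).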

Compound 3, half-maximal cytotoxic concentration: > 75500 nM
Compound 3 gave a limit, no number; the forecaster's own chance of this, stated with the estimate: 80%; the middle value does not contradict the limit.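

In this assay compound 1, compound 2 and compound 3 all give limits of the assay and not numbers, so no step among these three compounds can be read in size or direction. The compounds shown leave open what number each would give, and whether the group on the amide-type nitrogen affects this read-out at all.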